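The compounds below may be only part of what the source reports. "The series", "measured", "known", "first", "only" and "open" are said of these compounds alone.

Working notes on a short amide series built on a shared core. Compound 1 `CC(C)C[C@@H](N)C(=O)Nc1cc2cc[nH]c(=O)c2cc1Cl` and compound 2 `CC(C)[C@H](N)C(=O)Nc1cc2cc[nH]c(=O)c2cc1Cl` differ only in the group on the carbonyl carbon. In an assay on isolated protein for inhibition of Rho-associated protein kinase 2 (Homo sapiens) (on this read-out lower numbers stand for stronger inhibition and higher numbers for weaker inhibition), compound 1 gives 19 nM, and in this assay compound 2 gives 12 nM. Among the compounds with values here, the single measured step, a 1.6-fold lower number from compound 1 to compound 2 (0.20 log units; within the scatter), stays within the scatter. Compound 2 thus carries the lower of the two numbers, but it is not separated from compound 1 beyond the scatter, so no order between the two can be claimed.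

Compound 3 `N[C@H]1CC[C@H](C(=O)Nc2cc3cc[nH]c(=O)c3cc2Cl)CC1` is the next member and has not yet been measured. Its change from compound 2 is 4-aminocyclohexyl in place of 1-amino-2-methylpropyl on a carbonyl carbon. Within the data shown here, the one step available for comparison, a 1.6-fold lower number from compound 1 to compound 2 (0.20 log units; within the scatter), also exchanged one amino-bearing group for another on the same carbonyl carbon and did not move the number beyond the scatter. Among the measured compounds shown here, no measured pair shows a ring entering at this place, so the expectation rests on that single step alone. Compound 3 is therefore expected to give about 9 nM in this assay, with a range of 2.5 nM to 35 nM. The step this implies, a 1.3-fold lower number from compound 2 to compound 3 (0.12 log units; within the scatter), is expected to stay within the scatter.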

Compound 3, half-maximal inhibitory concentration: 330 nM
Estimate against measurement, compound 3: 37-fold (1.56 log units) below; the whole stated range lies below it.
By their numbers in this assay, from the lowest: compounds 2 and 1 (each within the scatter of the next); then compound 3.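

In this assay the group on this carbonyl carbon turns out to matter a great deal: 4-aminocyclohexyl in place of 1-amino-2-methylpropyl gives a 28-fold higher number from compound 2 to compound 3 (1.44 log units; beyond the scatter) and, in place of 1-amino-3-methylbutyl, gives a 17-fold higher number from compound 1 to compound 3 (1.24 log units; beyond the scatter) as the outcome, whereas the exchange between the two groups without a ring stayed within the scatter. The entering group brings one six-membered non-aromatic ring of carbon only and two defined stereocentres, while the hydrogen-bond donor and acceptor counts and the absence of net charge are the same as in the group that leaves, so those counts do not separate the groups. Nothing available here accounts for the size of this step.

With one ring-bearing group in the compounds shown, the ring itself cannot be separated from the placement of the amine on that ring. A 1-aminocyclohexyl group on the same carbonyl carbon would bear on that question, and a plain cyclohexyl group without the amine would show what the amine contributes on such a ring.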